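A few compounds are considered here, and "the series" means these few. Any claim that something is new, unique, unknown or untested is made for them only; others in the source may bear on it.

Measured compounds:
compound 1, `O=C(Nc1cc(C(F)(F)F)ccc1Nc1ccc(Br)cc1)c1ccccc1`, gives 11800 nM in a functional assay on HL-60 cells (Homo sapiens) for cytotoxicity, read by MTT assay, with a stated time of 48 h; a lower number here means a stronger inhibitor, a higher number a weaker inhibitor;
compound 2, `CCN(CC)c1ccc(C(F)(F)F)cc1NC(=O)c1ccncc1`, gives 89700 nM in this assay;
compound 3, `O=C(Nc1cc(C(F)(F)F)ccc1N1CCCC1)c1ccccc1`, gives "not active" (no number reported) in this assay, with no number attached.

Compound 3 therefore stands at the weak end of this small set, but where it stands on the numbers cannot be said: no single number exists for it, only the statement that it showed no activity. The step to compound 4, `CCN(CC)c1ccc(C(F)(F)F)cc1NC(=O)c1ccccc1`, changes one group: diethylamino in place of pyrrolidin-1-yl on an aromatic carbon. Both groups that are exchanged are built from the same count of heavy atoms and carry one hydrogen-bond acceptor each. Within the data shown here, no step between measured compounds exists to show what this exchange does in this assay, so the expected size of the step is small, in either direction, or none beyond the usual scatter. Compound 2, which carries the same diethylamino group beside a different amide, gives 89700 nM, and that value points toward weak inhibition for compound 4 as well. Compound 4 is estimated at 80000 nM, expected to fall between 20000 nM and 300000 nM.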

Compound 4, half-maximal inhibitory concentration: "not active" (no number reported)
The entry for compound 4 holds no number; there is nothing to compare the estimate with.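

In this assay, among these compounds, compound 3 and compound 4 are both reported as not active, with no number attached, so no step between them can be read. Going by these compounds, what exchanging pyrrolidin-1-yl for diethylamino does to potency stays open. Nothing shown offers an explanation for either result.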